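Trifluoromethyl added to a succinimide-derived anticonvulsant

The source may hold more compounds than are shown below. What is called first, only, known or untested is meant among the compounds shown, and "the series" means these compounds.

In a functional assay on the whole organism (strain Albino Swiss CD1) with Mus musculus as the target, in the maximal electroshock model (on this read-out higher numbers stand for an effect only at larger amounts of compound and lower numbers for an effect already at smaller amounts), compound 2 `CC1CC(=O)N(C(C)C(=O)NCc2ccccc2)C1=O` gives 106 mg/kg. The numbers for its neighbours sit within the usual scatter of this figure: compound 3 `CC1CC(=O)N(C(C)C(=O)NCc2ccccc2Cl)C1=O` gives 85.9 mg/kg, and compound 1 `CC(C(=O)NCc1ccc(C(F)(F)F)cc1)N1C(=O)CCC1=O` gives 80.1 mg/kg. Compound 4 `CC1CC(=O)N(C(C)C(=O)NCc2ccc(C(F)(F)F)cc2)C1=O` differs from compound 2 by trifluoromethyl in place of hydrogen on an aromatic carbon. Among the compounds with values here, the one step that bears on it is a 1.2-fold lower number from compound 2 to compound 3 (0.09 log units; within the scatter), an aromatic substitution that changed little. Compound 1 carries the same trifluoromethyl group on a different core, and its value and that of compound 2 also lie within the scatter. The step to compound 4 is therefore expected to be small, with no direction beyond the scatter, roughly a 1.2-fold lower number from compound 2 to compound 4 (0.10 log units; within the scatter). Compound 4 is estimated at 85 mg/kg, in a range from 55 mg/kg to 130 mg/kg.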

Compound 4, dose for half-maximal effect: > 150 mg/kg
Compound 4: a limit, no number (the forecaster's own chance of this, stated with the estimate: 5%); at least 1.7-fold (0.24 log units) between middle value and limit.
By their numbers in this assay, from the lowest: compounds 1, 3 and 2 (each within the scatter of the next). At a limit, above all of these: compound 4.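

Compound 4 ends at a limit of the assay, not a number: the limit of > 150 mg/kg in this assay, at which 1 of the 4 values shown sits.

Trifluoromethyl in place of hydrogen on the aromatic carbon gives an at least 1.4-fold higher number from compound 2 to compound 4 (0.15 log units; that floor lies within the scatter), and methyl in place of hydrogen on a saturated ring carbon gives an at least 1.8-fold higher number from compound 1 to compound 4 (0.27 log units; that floor lies within the scatter). Neither floor reaches beyond the scatter, but the same trifluoromethyl group gives no sign here of an effect at smaller amounts of compound.

Still open, going by these compounds, is how a fluorine atom or a methoxy group would read on this same aromatic carbon. The limit also leaves open what number compound 4 would give.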